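The source may hold more compounds than are shown below. What is called first, only, known or untested is meant among the compounds shown, and "the series" means these compounds.

Compound 3 `N#Cc1ccccc1Cc1cnc(CCc2ccc(-c3ccccc3C(=O)O)cc2)[nH]1` sits at the high end of the three numbers in hand: in an in vitro functional assay on cells for agonist activity at Bombesin receptor subtype-3 (Mus musculus), read by luminescence and calcium flux (a lower number here means that less compound is needed, a higher number that more compound is needed for the effect), compound 3 gives 642 nM, whereas compound 1 `O=C(O)c1ccccc1-c1ccc(CCc2ncc(CC3CCCCC3)[nH]2)cc1` gives 7.3 nM and compound 2 `O=C(O)c1ccccc1-c1ccc(CCc2ncc(CC3CCC3)[nH]2)cc1` gives 7.1 nM. The step to compound 4 `O=C(O)c1ccccc1-c1ccc(CCc2ncc(Cc3cccc(Cl)c3)[nH]2)cc1` replaces the aryl group on the saturated chain carbon: 3-chlorophenyl in place of 2-cyanophenyl on a saturated chain carbon bound to an aromatic carbon. Among the compounds with values here, no measured step swaps one aryl group for another at this carbon. Within the data shown here, the steps that bear on it are those into compound 3 itself: an 88-fold higher number from compound 1 to compound 3 (1.94 log units; beyond the scatter) and a 90-fold higher number from compound 2 to compound 3 (1.96 log units; beyond the scatter), both large, while a 1.0-fold lower number from compound 1 to compound 2 (0.01 log units; within the scatter) shows that the two saturated rings are interchangeable. Among the measured compounds shown here, since both aryl-bearing compounds share a six-membered aromatic ring on this carbon, and the data give no step between two such rings, the direction is open; the difference in what is counted, a nitrile lost and a chlorine gained, is expected to move the number moderately, and compound 4 is estimated at 200 nM, within 40 nM to 1000 nM, an expected step of a 3.2-fold lower number from compound 3 to compound 4 (0.51 log units; beyond the scatter).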

Compound 4, half-maximal effective concentration: 31 nM
For compound 4 the middle estimate is 6.5-fold (0.81 log units) above the measured one, outside the stated range (below it).
By their numbers in this assay, from the lowest: compounds 2 and 1 (each within the scatter of the next); then compound 4; then compound 3.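

In this assay, within the data shown here, 3-chlorophenyl in place of 2-cyanophenyl on the saturated chain carbon gives the first step between two aryl groups at this place (a 21-fold lower number from compound 3 to compound 4 (1.32 log units; beyond the scatter)), so a six-membered aromatic ring of carbon only does not by itself carry the high number of compound 3. The saturated rings still give lower numbers than 3-chlorophenyl, but these steps are modest (a 4.4-fold higher number from compound 2 to compound 4 (0.64 log units; beyond the scatter); a 4.2-fold higher number from compound 1 to compound 4 (0.63 log units; beyond the scatter)), so most of the large gap seen with 2-cyanophenyl does not apply to every aryl group here. Nothing available explains the difference between the two aryl groups.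

These two groups differ both in the substituent and in its printed position, so the compounds shown cannot separate nitrile from chlorine. Where 3-cyanophenyl, 2-chlorophenyl or plain phenyl would fall at this carbon remains open.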